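A few compounds are considered here, and "the series" means these few. Any claim that something is new, unique, unknown or untested is made for them only; others in the source may bear on it.

In an ADME assay on MT4 cells (Homo sapiens) for cytotoxicity (on this read-out higher numbers stand for lower toxicity in this test and lower numbers for higher toxicity in this test), compound 1 `COC(=O)N[C@H](C(=O)NN(CCC[C@@](O)(Cc1ccccc1)C(=O)N[C@H]1c2ccccc2C[C@H]1O)Cc1ccc(Br)cc1)C(C)(C)C` gives > 10000 nM as a limit of the assay and not a number. Compound 2 `COC(=O)N[C@H](C(=O)NN(CCC[C@@](O)(Cc1ccccc1)C(=O)N[C@H]1c2ccccc2C[C@H]1O)Cc1ccc(-c2nccs2)cc1)C(C)(C)C` gives > 10000 nM as a limit too, so no number places it. Compound 3 `COC(=O)N[C@H](C(=O)NN(CCC[C@@](O)(Cc1ccccc1)C(=O)N[C@H]1c2ccccc2C[C@H]1O)Cc1ccc(-c2csc(C)n2)cc1)C(C)(C)C` differs from compound 2 by 2-methyl-1,3-thiazol-4-yl in place of 1,3-thiazol-2-yl on an aromatic carbon with 2-methyl-1,3-thiazol-4-yl in place of 1,3-thiazol-2-yl on an aromatic carbon. Among the compounds with values here, the only measured step is a step that the two limits leave unreadable from compound 1 to compound 2 and it gives no size to carry over. Within the data shown here, with the limit of > 10000 nM in this assay, at which 2 of the 2 values shown sit, as the sole guide, the expected step that the limit leaves unreadable from compound 2 to compound 3 in this assay is none beyond the scatter. For compound 3 the expected value is 15000 nM with a range from 5000 nM to 50000 nM on this estimate.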

Compound 3, half-maximal cytotoxic concentration: > 10000 nM
Compound 3: a limit, no number; the forecaster's own chance of this, stated with the estimate: 85%; the middle value is on the limit's open side.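

Compound 3 gives a limit of the assay and not a number, so its steps from compound 1 and compound 2 cannot be read. The compounds shown leave open how far apart they truly stand in this assay, since all sit at one limit: the limit of > 10000 nM in this assay, at which 3 of the 3 values shown sit.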